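A few compounds are considered here, and "the series" means these few. Any claim that something is new, unique, unknown or untested is made for them only; others in the source may bear on it.

In a functional assay on ACHN cells (Homo sapiens) (a higher number here means a weaker inhibitor of growth, a lower number a stronger inhibitor of growth), compound 2 `O=S(=O)(/C=C/c1ccc(Br)cc1)Cc1ccc(Nc2ncnc3ccccc23)cc1` gives 200 nM, the lower of the two exact numbers available, while compound 1 `O=S(=O)(/C=C/c1ccc(Cl)c(Cl)c1)Cc1ccc(Nc2ncnc3ccccc23)cc1` gives 28000 nM. Compound 3 `CC(C)(C)c1cc(/C=C/S(=O)(=O)Cc2ccc(Nc3ncnc4ccccc34)cc2)cc(C(C)(C)C)c1O` returned only a limit, > 100000 nM.

Compound 4 `O=S(=O)(/C=C/c1ccc(F)cc1Cl)Cc1ccc(Nc2ncnc3ccccc23)cc1` keeps the rest of compound 2 but has 2-chloro-4-fluorophenyl in place of 4-bromophenyl, on a double-bonded chain carbon bound to a double-bonded chain carbon: 2-chloro-4-fluorophenyl in place of 4-bromophenyl on a double-bonded chain carbon bound to a double-bonded chain carbon.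

Among the compounds with values here, only one measured step changes this group directly: a 140-fold lower number from compound 1 to compound 2 (2.15 log units; beyond the scatter). This large step, beyond the scatter, replaced 3,4-dichlorophenyl with 4-bromophenyl. The incoming group in compound 4 carries chlorine, as the group in compound 1 does, so part of that step may be given back. A higher number than that of compound 2 is therefore expected, though a single step is thin evidence and the size is uncertain.

The expected change is a 13-fold higher number from compound 2 to compound 4 (1.10 log units; beyond the scatter). Compound 4 is estimated at 2500 nM, with an expected range from 250 nM to 25000 nM.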

Compound 4, concentration for 50% growth inhibition: 73000 nM
Beside the measured number, compound 4's estimate is 29-fold (1.47 log units) below it; measured number outside the range, above it.
By their numbers in this assay, from the lowest: compound 2; then compound 1; then compound 4. At a limit, above all of these: compound 3.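

Replacing 4-bromophenyl with 2-chloro-4-fluorophenyl gives a 370-fold higher number from compound 2 to compound 4 (2.56 log units; beyond the scatter), so a second case now shows that growth inhibition at this place depends strongly on what the ring carries. The two chlorine-bearing groups differ far less, with a 2.6-fold higher number from compound 1 to compound 4 (0.42 log units; beyond the scatter), so the low number of compound 2 is not set apart by 3,4-dichlorophenyl alone: 4-bromophenyl is the group that stands out here. Compound 3, whose group carries no chlorine, gives only a limit, not a number, so chlorine cannot be the sole mark of a weak compound: the limit of > 100000 nM in this assay, at which 1 of the 4 values shown sits.

Going by these compounds, whether bromine itself matters or simply the lack of a second ring substituent remains open. 4-Chlorophenyl, 4-fluorophenyl or plain phenyl at this place would separate those two readings.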